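Nitro to cyano on the pendant aryl ring

The source may report more compounds than this note shows. Statements on the series, on what has been measured and on what is new or still open speak of the compounds shown alone.

Measured so far in a functional assay on NCI-H460 cells (Homo sapiens) for inhibition, with a stated time of 72 h; a higher number here means a weaker inhibitor, a lower number a stronger inhibitor:
compound 1 `COc1ccc(S(=O)(=O)N2CCc3cccc(-c4ccc(N)cc4)c32)cc1` gives 288 nM
compound 2 `COc1ccc(S(=O)(=O)N2CCc3cccc(-c4ccc([N+](=O)[O-])cc4)c32)cc1` gives 53.1 nM
compound 3 `COc1ccc(S(=O)(=O)N2CCc3cccc(-c4cccc(F)c4)c32)cc1` gives 167 nM

Compound 2 gives the lowest number of the three in this assay; compound 3 sits at a 3.1-fold higher number from compound 2 to compound 3 (0.50 log units; beyond the scatter) and compound 1 at a 5.4-fold lower number from compound 1 to compound 2 (0.73 log units; beyond the scatter) in the opposite sense. Compound 4 `COc1ccc(S(=O)(=O)N2CCc3cccc(-c4ccc(C#N)cc4)c32)cc1` differs from compound 2 as follows: cyano in place of nitro on an aromatic carbon. Going by the values given here, no measured step exchanges nitro for cyano, so the bearing steps are indirect: the amino-to-nitro step a 5.4-fold lower number from compound 1 to compound 2 (0.73 log units; beyond the scatter) and the nitro-to-fluorophenyl step a 3.1-fold higher number from compound 2 to compound 3 (0.50 log units; beyond the scatter), both moving away from compound 2 with a modest rise in number. The cyano change is expected to behave likewise but more mildly, estimated as a 1.7-fold higher number from compound 2 to compound 4 (0.23 log units; within the scatter). Compound 4 is therefore expected at 90 nM, within 35 nM to 250 nM.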

Compound 4, half-maximal inhibitory concentration: 29.5 nM
Beside the measured number, compound 4's estimate is 3.1-fold (0.48 log units) above it; the measured number lies below the stated range.
By their numbers in this assay, from the lowest: compounds 4 and 2 (each within the scatter of the next); then compounds 3 and 1 (each within the scatter of the next).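

In this assay the nitro group is not required for a low number at this position: cyano, with fewer heavy atoms, stays within the scatter of it (a 1.8-fold lower number from compound 2 to compound 4 (0.26 log units; within the scatter)). The 4-cyanophenyl group therefore stands with 4-nitrophenyl and apart from the other two aryl groups, with both steps beyond the scatter (a 5.7-fold lower number from compound 3 to compound 4 (0.75 log units; beyond the scatter); a 9.8-fold lower number from compound 1 to compound 4 (0.99 log units; beyond the scatter)). Nothing measured here offers a reason for this result. Still open, from the compounds shown here alone, is whether a carboxylic acid, an amide or a methyl ester in this place would hold the number, and whether cyano would do so on another carbon of the ring.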